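Swapping the aryl group on a hexacyclic core

A few compounds are considered here, and "the series" means these few. Any claim that something is new, unique, unknown or untested is made for them only; others in the source may bear on it.

Measured compounds:
Compound 1, `Cc1nc2c3ccccc3ccc2c2nc3c(ccc4ccccc43)c(-c3ccccc3Cl)c12`: 170 ug/mL
Compound 2, `Cc1nc2c3ccccc3ccc2c2nc3c(ccc4ccccc43)c(-c3nccnc3N)c12`: 134 ug/mL

In a functional assay, with a stated time of 90 s (on this read-out lower numbers stand for stronger inhibition and higher numbers for weaker inhibition), compound 1 gives 170 ug/mL, and compound 2 gives 134 ug/mL. Among the compounds with values here, the only step available is a 1.3-fold lower number from compound 1 to compound 2 (0.10 log units; within the scatter), so the two measured numbers cannot be told apart on this assay, and compound 1 does not stand apart from compound 2.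

Compound 3, `Cc1nc2c3ccccc3ccc2c2nc3c(ccc4ccccc43)c(-c3ccc(O)cc3)c12`, is not yet measured. It differs from compound 1 by 4-hydroxyphenyl in place of 2-chlorophenyl on an aromatic carbon. Within the data shown here, the one measured step at the same aromatic carbon, a 1.3-fold lower number from compound 1 to compound 2 (0.10 log units; within the scatter), replaced the 2-chlorophenyl with a different ring and did not move the number beyond the scatter. Among the measured compounds shown here, no step with a 4-hydroxyphenyl has been measured. On this basis compound 3 is expected to show a 1.1-fold lower number from compound 1 to compound 3 (0.03 log units; within the scatter) in this assay, meaning a step that does not rise beyond the scatter. The estimate for compound 3 is 160 ug/mL, with a range from 80 ug/mL to 320 ug/mL.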

Compound 3, half-maximal inhibitory concentration: 99 ug/mL
The estimate for compound 3 lay 1.6-fold (0.21 log units) above the measured number; measured number inside the range.
By their numbers in this assay, from the lowest: compounds 3, 2 and 1 (each within the scatter of the next).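

In this assay, swapping the 2-chlorophenyl for a 4-hydroxyphenyl gives a 1.7-fold lower number from compound 1 to compound 3 (0.23 log units; within the scatter), and 4-hydroxyphenyl in place of 3-aminopyrazin-2-yl gives a 1.4-fold lower number from compound 2 to compound 3 (0.13 log units; within the scatter) in the same assay. Within the data shown here, the position has now taken a third aryl group, this one with a hydrogen-bond donor and acceptor that 2-chlorophenyl does not have, and no step among the three compounds rises beyond the scatter. No evidence is at hand that would account for this.

The compounds shown leave open whether any group at this carbon can move the number beyond the scatter. Going by these compounds, it also remains open whether a non-ring group, such as an amine, a carboxylic acid or a longer alkyl chain, would behave like the three aryl groups.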